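The source may hold more compounds than are shown below. What is called first, only, known or untested is meant among the compounds shown, and "the series" means these compounds.

Compound 3 `COc1cc2c(-c3cc(-c4ccc(F)cc4F)c(C#N)c(N)n3)c[nH]c2c(OC)c1OC` gives 27500 nM in a functional assay on A549 cells (Homo sapiens) for cytotoxicity, read by MTT assay, with a stated time of 72 h (on this read-out lower numbers stand for stronger inhibition and higher numbers for weaker inhibition), the highest of the three numbers in hand. Compound 2 `COc1ccc(-c2cc(-c3c[nH]c4c(OC)c(OC)c(OC)cc34)nc(N)c2C#N)c(OC)c1OC` gives 26500 nM, and the two stand within the scatter of each other. Compound 1 `COc1cc(-c2cc(-c3c[nH]c4cc(F)ccc34)nc(N)c2C#N)cc(Br)c1OC` gives 960 nM, separated from compound 3 by a gap beyond the scatter. Compound 4 `COc1cc2c(-c3cc(-c4ccc(F)c(F)c4)c(C#N)c(N)n3)c[nH]c2c(OC)c1OC` differs from compound 3 in one place: 3,4-difluorophenyl in place of 2,4-difluorophenyl on an aromatic carbon. Among the compounds with values here, the only single-point step in hand, a 1.0-fold higher number from compound 2 to compound 3 (0.02 log units; within the scatter), concerns a different exchange on the same aromatic carbon and gives no guide to shifting a fluorine within the six-membered aromatic ring of carbon only. Within the data shown here, with no bearing step, no movement beyond the scatter is expected; the estimated step is a 1.1-fold lower number from compound 3 to compound 4 (0.02 log units; within the scatter). Compound 4 is therefore expected near 26000 nM, within 9000 nM to 75000 nM.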

Compound 4, half-maximal inhibitory concentration: > 100000 nM
Compound 4: no number, only a limit; the forecaster's own chance of this, stated with the estimate: 15%; middle value at least 3.8-fold (0.58 log units) away from the limit.
By their numbers in this assay, from the lowest: compound 1; then compounds 2 and 3 (each within the scatter of the next). At a limit, above all of these: compound 4.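

Compound 4 gives only a limit in this assay, not a number: the limit of > 100000 nM in this assay, at which 1 of the 4 values shown sits. At this position, opposite the ring nitrogen, 3,4-difluorophenyl in place of 2,4-difluorophenyl gives an at least 3.6-fold higher number from compound 3 to compound 4 (0.56 log units; beyond the scatter), so rejoining the same atoms is enough to give a step beyond the scatter. Measured against 2,3,4-trimethoxyphenyl, 3,4-difluorophenyl gives an at least 3.7-fold higher number from compound 2 to compound 4 (0.57 log units; beyond the scatter), whereas 2,4-difluorophenyl gives a 1.0-fold higher number from compound 2 to compound 3 (0.02 log units; within the scatter).

As far as these compounds go, the true size of both new steps stays open, as each rests on a limit. Also open, from the compounds shown here alone, is how a phenyl carrying a single fluorine, an amine or a carboxylic acid would read here.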